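This account rests on a few compounds, and the source may have more. Where it says the series, first, only, none or still open, it means among the compounds named here.

Compound 1 `C/C(=N\NC(=O)c1ccncc1)C(=O)Nc1ccc(F)cc1` was examined in a functional assay on HepG2 cells (Homo sapiens) for cytotoxicity, read by MTT assay, with a stated time of 72 h; on this read-out higher numbers stand for weaker inhibition and lower numbers for stronger inhibition. In this assay compound 1 gives only a limit, > 50000 nM. Compound 2 `C/C(=N\NC(=O)c1ccncc1)C(=O)Nc1ccc(OC(F)(F)F)cc1` likewise returns only a limit in this assay, > 50000 nM. Compound 3 `C/C(=N\NC(=O)c1ccncc1)C(=O)Nc1cccc(Cl)c1` also returns only a limit in this assay, > 50000 nM. Replacing fluoro with trifluoromethoxy on an aromatic carbon gives a step that the two limits leave unreadable from compound 1 to compound 2, and replacing 4-fluorophenyl with 3-chlorophenyl on an amide-type nitrogen gives a step that the two limits leave unreadable from compound 1 to compound 3. Both steps run into (the limit of > 50000 nM in this assay, at which 3 of the 3 values shown sit), so neither has a readable size or direction. Compound 4 `C/C(=N\NC(=O)c1ccncc1)C(=O)Nc1ccc(Cl)cc1` has not yet been measured in this assay; it differs from compound 1 by chloro in place of fluoro on an aromatic carbon. The measured steps give no sign that a small change of this kind moves the read-out off the limit. Compound 4 is therefore expected to give 80000 nM, within 30000 nM to 300000 nM, and most probably it will again be reported only as a limit. The expected step from compound 1 to compound 4 is a step that the limit leaves unreadable from compound 1 to compound 4.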

Compound 4, half-maximal inhibitory concentration: > 50000 nM
Compound 4 gave a limit, no number; the forecaster's own chance of this, stated with the estimate: 85%; the middle value is on the limit's open side.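

Compound 4, like compound 1, compound 2 and compound 3, returns only a limit in this assay, so no step to compound 4 from any of them can be read: the limit of > 50000 nM in this assay, at which 4 of the 4 values shown sit.

The compounds shown leave open whether any change on the shared core would give a true number in this assay.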